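This account rests on a few compounds, and the source may have more. Where it says the series, first, only, none or still open, it means among the compounds named here.

Measured compounds:
compound 1, `Cc1ccccc1C(=O)Nc1cccc(-c2oc3cc(-c4ccc(F)cc4)ccc3c(=O)c2O)c1`, 4910 nM
compound 2, `Cc1cccc(C(=O)Nc2cccc(-c3oc4cc(-c5ccc(F)cc5)ccc4c(=O)c3O)c2)c1`, 2840 nM

Both numbers come from a functional assay on MDA-MB-231 cells (Homo sapiens) for antiproliferative activity, read by CCK-8 assay, with a stated time of 72 h; on this read-out higher numbers stand for weaker inhibition and lower numbers for stronger inhibition. Going by the values given here, compound 2 holds the lower of the two numbers in this assay, but its only neighbour is compound 1, and the step of a 1.7-fold lower number from compound 1 to compound 2 (0.24 log units; within the scatter) lies within the scatter, so the two cannot be ranked against each other.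

Compound 3, `O=C(Nc1cccc(-c2oc3cc(-c4ccc(F)cc4)ccc3c(=O)c2O)c1)c1cccc(F)c1`, is unmeasured. It differs from compound 2 by fluoro in place of methyl on an aromatic carbon. Among the compounds with values here, no measured step changes a methyl for a fluoro; the one step that exists, a 1.7-fold lower number from compound 1 to compound 2 (0.24 log units; within the scatter), moves the methyl from one ring position to another and does not bear on the exchange of the group itself. Within the data shown here, on these data a change of one small substituent for another at the same place has no precedent, and the only known step is small. Compound 3 is therefore expected to land close to compound 2, with the step of a 1.1-fold higher number from compound 2 to compound 3 (0.02 log units; within the scatter) expected to stay within the scatter in this assay. The estimate for compound 3 is 3000 nM, with a range from 1200 nM to 7500 nM.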

Compound 3, half-maximal inhibitory concentration: 2510 nM
For compound 3 the middle estimate is 1.2-fold (0.08 log units) above the measured one, and the stated range covers the measured number.
By their numbers in this assay, from the lowest: compounds 3, 2 and 1 (each within the scatter of the next).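

The exchange of the group itself, 3-methylphenyl to 3-fluorophenyl on the carbonyl carbon of the amide, gives a 1.1-fold lower number from compound 2 to compound 3 (0.05 log units; within the scatter) in this assay and so does not separate methyl from fluoro at this place. The wider step, 3-fluorophenyl in place of 2-methylphenyl, gives a 2.0-fold lower number from compound 1 to compound 3 (0.29 log units; within the scatter) and also stays within the scatter, so neither the swap of substituent alone nor the swap together with the change from the 2-methylphenyl group has yet produced a readable difference in this series. No accompanying data bear on this result.

Still open, from the compounds shown here alone, is whether a group of a different kind on this aromatic ring, such as an amine, a carboxylic acid or a longer chain, would move the number beyond the scatter, or whether this place tolerates such groups as it does methyl and fluoro. Also open is whether changes elsewhere on the shared core, away from this ring, would produce larger steps than the ones seen among these three compounds.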